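The compounds below may be only part of what the source reports. "The series", "measured", "known", "first", "only" and "open" are said of these compounds alone.

Compound 1 `O=c1ccoc2cc(OCc3cn(Cc4cccc(F)c4)nn3)ccc12` was tested in a functional assay on SGC-7901 cells (Homo sapiens) for cytotoxicity, read by MTT assay, with a stated time of 48 h; on this read-out lower numbers stand for stronger inhibition and higher numbers for weaker inhibition. In this assay compound 1 gives > 100000 nM, which is a limit of the assay. Compound 2 `O=c1ccoc2cc(OCc3cn(Cc4cccc(Br)c4)nn3)ccc12` carries bromo in place of fluoro on an aromatic carbon, and in this assay compound 2 gives > 100000 nM, again a limit. Compound 3 `O=c1ccoc2cc(OCc3cn(Cc4ccccc4Cl)nn3)ccc12` carries 2-chlorophenyl in place of 3-fluorophenyl on a saturated chain carbon bound to an aromatic nitrogen, and in this assay compound 3 gives > 100000 nM, once more a limit. The steps among these three, a step that the two limits leave unreadable from compound 1 to compound 2, a step that the two limits leave unreadable from compound 1 to compound 3 and a step that the two limits leave unreadable from compound 2 to compound 3, cannot be read in size or direction because of the limit of > 100000 nM in this assay, at which 3 of the 3 values shown sit.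

Compound 4 `O=c1ccoc2cc(OCc3cn(Cc4ccccc4)nn3)ccc12` has not yet been measured. It differs from compound 1 in one place: hydrogen in place of fluoro on an aromatic carbon. Within the data shown here, none of the measured steps has a readable size, so there is no ground to expect a step beyond the scatter in either direction. The step from compound 1 to compound 4 is therefore expected to be a step that the limit leaves unreadable from compound 1 to compound 4. Compound 4 is estimated to give about 120000 nM, within a range from 40000 nM to 400000 nM, most probably reported only as a limit.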

Compound 4, half-maximal inhibitory concentration: > 100000 nM
Compound 4 gave a limit, no number; the forecaster's own chance of this, stated with the estimate: 85%; the middle value lies beyond the limit too.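

In this assay compound 4 gives > 100000 nM, which is a limit and not a number. Its steps to compound 1, compound 2 and compound 3 cannot be read, because all of them share one limit: the limit of > 100000 nM in this assay, at which 4 of the 4 values shown sit.

The compounds shown leave open whether a fluoro, bromo or chloro group on the benzyl changes activity at all.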